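Changing the Aryl Group on the Amine of Compound 1

This account rests on a few compounds, and the source may have more. Where it says the series, first, only, none or still open, it means among the compounds named here.

In a functional assay on KB cells (Homo sapiens) for cytotoxicity, read by sulforhodamine B assay (a higher number here means a weaker inhibitor, a lower number a stronger inhibitor), compound 1 `C=C1[C@@H](OC(C)=O)C[C@@H]2[C@](C)(COC=O)[C@H](OC(C)=O)CC[C@@]2(C)[C@@H]1C[C@@H](Nc1ccc(O)cc1)C1=CCOC1=O` gives 28900 nM, the highest number among the three compounds measured. Compound 3 `C=C1[C@@H](OC(C)=O)C[C@@H]2[C@](C)(CO[Si](C)(C)C(C)(C)C)[C@H](OC(C)=O)CC[C@@]2(C)[C@@H]1C[C@@H](Nc1ccc(O)cc1)C1=CCOC1=O` gives 8350 nM, and compound 2 `C=C1[C@@H](OC(C)=O)C[C@@H]2[C@](C)(CO[Si](C)(C)C(C)(C)C)[C@H](OC(C)=O)CC[C@@]2(C)[C@@H]1C/C=C1/C(=O)OC[C@H]1OC(C)=O` gives 5020 nM.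

Compound 4 `C=C1[C@@H](OC(C)=O)C[C@@H]2[C@](C)(COC=O)[C@H](OC(C)=O)CC[C@@]2(C)[C@@H]1C[C@@H](Nc1cccc2ccccc12)C1=CCOC1=O` keeps the core of compound 1 and has naphthalen-1-yl in place of 4-hydroxyphenyl on an amine nitrogen. Among the measured compounds shown here, no measured step changes this group, so the data offer no direct comparison. For the measured compounds named here, the only single-place evidence is a 3.5-fold lower number from compound 1 to compound 3 (0.54 log units; beyond the scatter), which comes from a change on an oxygen on a saturated carbon, not on the amine nitrogen. That step bears on the new change only loosely, showing that one exchange in this small set can shift the number modestly. A step of similar modest size towards a lower number is therefore expected, though with little certainty about its direction. The estimate corresponds to an expected 2.1-fold lower number from compound 1 to compound 4 (0.31 log units; beyond the scatter). Compound 4 is expected to give 14000 nM, with an estimated range of 4500 nM to 40000 nM.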

Compound 4, half-maximal inhibitory concentration: 32300 nM
Compound 4: middle estimate off by 2.3-fold (0.36 log units), on the low side, within the range that was stated.
By their numbers in this assay, from the lowest: compounds 2 and 3 (each within the scatter of the next); then compounds 1 and 4 (each within the scatter of the next).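

In this assay, among the compounds shown here, naphthalen-1-yl in place of 4-hydroxyphenyl on the amine nitrogen gives a 1.1-fold higher number from compound 1 to compound 4 (0.05 log units; within the scatter), the first measured step at this position, and it leaves compound 1 and compound 4 within the scatter of each other. This exchange removes the hydrogen-bond donor and acceptor of the 4-hydroxyphenyl and brings a second six-membered aromatic ring, yet the two compounds cannot be told apart in this assay. Nothing available explains why the number stays level across these two aryl groups.

As far as these compounds go, whether a plain phenyl, a 4-aminophenyl or a 4-carboxyphenyl on the amine nitrogen would also stay level with compound 1 remains open. Also open, from the compounds shown here alone, is whether naphthalen-1-yl would give a similar result on the core of compound 3.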